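Replacing a Nitrile with a Tetrazole on Compound 3

The source may report more compounds than this note shows. Statements on the series, on what has been measured and on what is new or still open speak of the compounds shown alone.

Of the compounds shown here, three have been measured so far in an assay for binding affinity to 17-beta-hydroxysteroid dehydrogenase 14 (Homo sapiens), read by fluorescence, with a stated time of 15 min, in the presence of a further agent that is not named here; a higher number here means a weaker inhibitor, a lower number a stronger inhibitor. Compound 1 `Oc1cc(Oc2cccc(-c3cccc(O)c3F)n2)ccc1F` gives 58 nM in this assay. Compound 2 `C=C(c1ccc(F)c(O)c1)c1cccc(-c2cccc(O)c2F)n1` gives 1.5 nM in this assay. Compound 3 `N#Cc1ccc2ccc(C(=O)c3ccc(F)c(O)c3)nc2c1` gives 9 nM in this assay, which is the second highest of the three numbers; the nearest number is that of compound 2, which lies below it by a margin beyond the scatter, and the furthest is that of compound 1, which lies above it by a margin that is also beyond the scatter. No two of these compounds differ in a single place, so none of these gaps can be tied to one structural change.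

Compound 4 `O=C(c1ccc(F)c(O)c1)c1ccc2ccc(-c3nnn[nH]3)cc2n1` has not yet been measured. It differs from compound 3 in one place: 1H-tetrazol-5-yl in place of cyano on an aromatic carbon. Within the data shown here, no measured pair shows this kind of replacement, so the measured numbers give no size for the step. Compound 4 is expected to give about 15 nM in this assay, with a range from 3 nM to 80 nM. The step this estimate means, a 1.7-fold higher number from compound 3 to compound 4 (0.22 log units; within the scatter), is expected to be small, either within the scatter or a modest move toward a higher number.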

Compound 4, inhibition constant: 10 nM
The estimate for compound 4 lay 1.5-fold (0.18 log units) above the measured number; low and high end bracket the measured number.
By their numbers in this assay, from the lowest: compound 2; then compounds 3 and 4 (each within the scatter of the next); then compound 1.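

In this assay, the exchange of cyano for 1H-tetrazol-5-yl gives a 1.1-fold higher number from compound 3 to compound 4 (0.05 log units; within the scatter), so this step lies within the scatter and the two compounds cannot be told apart. Among these compounds, this is the first change in the set that is confined to one place, and it shows that this aromatic carbon, on a six-membered aromatic ring of carbon only that is part of a fused or bridged system of two rings, can carry a five-membered aromatic ring with 4 hetero atoms and 5 heavy atoms in place of 2 without a shift beyond the scatter; the entering group also brings 1 hydrogen-bond donor, which cyano does not have, and this too goes with no change in the number that can be read. No supporting measurement bears on this result, and what lies behind it stays unexplained.

As far as these compounds go, whether a carboxylic acid or a primary amide on the same aromatic carbon would also stay within the scatter remains open. The compounds shown also leave open what a plain hydrogen at this place would give, and so whether any group here matters to the number at all.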